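The source may report more compounds than this note shows. Statements on the series, on what has been measured and on what is new or still open speak of the compounds shown alone.

Measured so far in an assay for inhibition of Polyunsaturated fatty acid 5-lipoxygenase (Homo sapiens), read by spectrophotometry, tested at 10 uM, in the presence of a further agent that is not named here; on this read-out higher numbers stand for more inhibition at the one concentration tested (going by the name of the read-out) and lower numbers for less inhibition: compound 1 `Cc1nc(NC(=O)c2ccccc2)sc1C(=O)/C=C/c1ccc(F)cc1` gives 98%; compound 2 `Cc1nc(NC(=O)c2ccccc2)sc1C(=O)/C=C/c1cccc(Br)c1` gives 42.5%; compound 3 `COc1ccc(/C=C/C(=O)c2sc(NC(=O)c3ccccc3)nc2C)cc1` gives 58.8%.

Compound 3 stands between the other two, with a number 16.3 percentage points higher from compound 2 to compound 3 (beyond the scatter) and a number 39.2 percentage points lower from compound 1 to compound 3 (beyond the scatter). Compound 4 `Cc1nc(NC(=O)c2ccccc2)sc1C(=O)/C=C/c1ccc(N(C)C)cc1` differs from compound 3 in one place: dimethylamino in place of methoxy on an aromatic carbon. For the measured compounds named here, two measured steps concern the same place on that ring, a number 39.2 percentage points lower from compound 1 to compound 3 (beyond the scatter) and a number 16.3 percentage points higher from compound 2 to compound 3 (beyond the scatter), both beyond the scatter, so changing the group there has moved the reading strongly. Going by the values given here, no measured pair shows which way a dimethylamino group would move it. A sizeable step in either direction is therefore possible, and the estimate is kept near compound 3 with a wide range. Compound 4 is expected to give 55%, from 20% to 90%. This estimate means an expected step of a number 3.8 percentage points lower from compound 3 to compound 4 (within the scatter).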

Compound 4, a percentage reported as inhibition, at one concentration (the size of the read-out at that concentration, not a potency): 88.2%
Compound 4: middle estimate off by 33.2 percentage points, on the low side; low and high end bracket the measured number.
By their numbers in this assay, from the lowest: compound 2; then compound 3; then compounds 4 and 1 (each within the scatter of the next).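

In this assay, dimethylamino in place of methoxy on this aromatic carbon gives a number 29.4 percentage points higher from compound 3 to compound 4 (beyond the scatter), so these two groups are clearly distinguished here. The change from the 3-bromophenyl compound gives a number 45.7 percentage points higher from compound 2 to compound 4 (beyond the scatter). With dimethylamino in place of fluoro, the result is a number 9.8 percentage points lower from compound 1 to compound 4 (within the scatter), so a high reading at this position is not confined to fluoro.

Nothing available explains why these groups differ. Going by these compounds, it remains open whether a primary amine or a carboxylic acid on the same carbon would match dimethylamino and fluoro or fall towards methoxy.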